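A Silicon-Bearing Group on the Oxygen of Compound 1

This account rests on a few compounds, and the source may have more. Where it says the series, first, only, none or still open, it means among the compounds named here.

Compound 1 (`COC(=O)N[C@H](C(=O)NN(CCC[C@@](O)(Cc1ccccc1)C(=O)N[C@H]1c2ccccc2C[C@H]1O)Cc1ccc(Br)cc1)C(C)(C)C`) is the starting point for this step. In an ADME assay on MT4 cells (Homo sapiens) for cytotoxicity (on this read-out lower numbers stand for higher toxicity in this test and higher numbers for lower toxicity in this test), compound 1 gives > 10000 nM, which is a limit of the assay and not a number. Compound 2 (`COC(=O)N[C@H](C(=O)NN(CCC[C@@](O)(Cc1ccccc1)C(=O)N[C@H]1c2ccccc2C[C@H]1O)Cc1ccc(-c2nc(C(C)(C)C)cs2)cc1)C(C)(C)C`) gives > 10000 nM, which is also a limit. The picture so far is the limit of > 10000 nM in this assay, at which 2 of the 2 values shown sit.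

Compound 3 (`COC(=O)N[C@H](C(=O)NN(CCC[C@](Cc1ccccc1)(O[Si](C)(C)C(C)(C)C)C(=O)N[C@H]1c2ccccc2C[C@H]1O)Cc1ccc(Br)cc1)C(C)(C)C`) differs from compound 1 in one place: a group of 7 heavy atoms (6 carbon, 1 silicon; no ring) in place of a hydrogen atom, on an oxygen on a saturated carbon. The group enters on an oxygen on a saturated carbon, replacing a hydrogen atom.

For the measured compounds named here, only one measured step is available, a step that the two limits leave unreadable from compound 1 to compound 2. It changes an aromatic carbon rather than this oxygen, and it has no readable size, so it bears on the new change only weakly. No clear shift in this assay is therefore expected in either direction, although the data cannot rule one out. The expected change is a step that the limit leaves unreadable from compound 1 to compound 3. Compound 3 is estimated at 12000 nM, with an expected range of 4000 nM to 40000 nM.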

Compound 3, half-maximal cytotoxic concentration: 5800 nM
Estimate against measurement, compound 3: 2.1-fold (0.32 log units) above; the range from low to high includes it.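

For the compounds shown here, compound 3 is the first compound here whose result in this assay is a number and not a limit, so this oxygen on a saturated carbon now has a readable value with the group of 7 heavy atoms (6 carbon, 1 silicon; no ring) in place of a hydrogen atom. The change reads as an at least 1.7-fold lower number from compound 1 to compound 3 (0.23 log units; that floor lies within the scatter); that figure is only a floor, so the real step may be larger, but the floor itself does not clear the usual scatter of repeated measurements, and a real shift is therefore suggested, not shown. The comparison stays one-sided, with a number on only one of its two sides: the limit of > 10000 nM in this assay, at which 2 of the 3 values shown sit.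

The compounds shown leave open how large the step truly is, and whether silicon matters at all or a simple methyl group or an acetyl group on the same oxygen would give a similar number. Also open, going by these compounds, is whether the same group of 7 heavy atoms would lower the number on the oxygen of compound 2 as well.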